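Swapping the benzyl group on a shared adenosine core

The compounds below may be only part of what the source reports. "The series", "measured", "known", "first", "only" and "open" are said of these compounds alone.

Compound 1 `CNC(=O)[C@]12C[C@@H]1[C@@H](n1cnc3c(NCc4cccc(Cl)c4)nc(C#Cc4ccc(F)c(F)c4)nc31)[C@H](O)[C@@H]2O`: >= 99 nM
Compound 2 `CNC(=O)[C@]12C[C@@H]1[C@@H](n1cnc3c(NCc4cccc(Cl)c4)nc(C#Cc4ccccc4)nc31)[C@H](O)[C@@H]2O`: >= 99 nM
Compound 3 `CNC(=O)[C@]12C[C@@H]1[C@@H](n1cnc3c(NCc4cccc(Cl)c4)nc(C#Cc4ccc(F)cc4)nc31)[C@H](O)[C@@H]2O`: >= 99 nM

In an assay on isolated protein for binding affinity to adenosine receptor A3 (Homo sapiens) (a higher number here means a weaker inhibitor, a lower number a stronger inhibitor), compound 1 gives >= 99 nM, which is a limit of the assay and not a number. Compound 2 likewise gives >= 99 nM, a limit. Compound 3 gives >= 99 nM, again a limit. All three sit at the limit of >= 99 nM in this assay, at which 3 of the 3 values shown sit, so none can be ranked against the others: the step that the two limits leave unreadable from compound 1 to compound 2, the step that the two limits leave unreadable from compound 1 to compound 3 and the step that the two limits leave unreadable from compound 2 to compound 3 all stay unreadable, and compound 1 stands only at the limit, with no number of its own.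

Compound 4 `CNC(=O)[C@]12C[C@@H]1[C@@H](n1cnc3c(NCc4ccc(N=[N+]=[N-])cc4)nc(C#Cc4ccc(F)c(F)c4)nc31)[C@H](O)[C@@H]2O` differs from compound 1 by 4-azidophenyl in place of 3-chlorophenyl on a saturated chain carbon bound to a nitrogen on an aromatic ring. Among the compounds with values here, none of the measured steps touches this part of the molecule; the three measured changes all sit on the triple-bonded carbon and all left the readout at the limit. Within the data shown here, no measured step therefore bears on the change to compound 4, and the expectation rests on the fact that every measured compound remained weak. Compound 4 is expected to give about 300 nM, within 99 nM to 3000 nM, most likely reported as a limit once more. The step from compound 1 is thus expected to be a step that the limit leaves unreadable from compound 1 to compound 4, not readable beyond the limit.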

Compound 4, inhibition constant: >= 99 nM
Compound 4: a limit, no number (the forecaster's own chance of this, stated with the estimate: 80%); the middle value does not contradict the limit.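

No step from compound 1 to compound 4 can be read, because both compounds, like compounds 2 and 3, stand at a limit and not a number: the limit of >= 99 nM in this assay, at which 4 of the 4 values shown sit.

The compounds shown leave open how strong any of them is, and whether 4-azidophenyl differs from 3-chlorophenyl at all.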